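Piperidine benzyl substituent changes in the shared core

A few compounds are considered here, and "the series" means these few. Any claim that something is new, unique, unknown or untested is made for them only; others in the source may bear on it.

Measured so far in an in vitro functional assay on RBL cells for antagonist activity at C-C chemokine receptor type 8 (Homo sapiens), read by FLIPR and calcium flux; a higher number here means a weaker inhibitor, a lower number a stronger inhibitor:
compound 1, `COc1ccc2nccc(C3CN(C4CCN(Cc5c[nH]c6ccccc56)CC4)C(=O)O3)c2c1`: < 50200 nM, a limit of the assay, not a number
compound 2, `COc1ccc2nccc(C3CN(C4CCN(Cc5ccc6ccccc6c5)CC4)C(=O)O3)c2c1`: 1260 nM
compound 3, `COc1ccc2nccc(C3CN(C4CCN(CC5CCCCC5)CC4)C(=O)O3)c2c1`: 7940 nM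

Among the two numbers given, compound 3 holds the highest; the nearest is compound 2, and the step of a 6.3-fold higher number from compound 2 to compound 3 (0.80 log units; beyond the scatter) lies beyond the scatter. The limit for compound 1 is recorded as the limit of < 50200 nM in this assay, at which 1 of the 3 values shown sits, so the steps from compound 1 to compound 2 and to compound 3 cannot be read.

Compound 4, `COc1ccc2nccc(C3CN(C4CCN(Cc5ccc(Cl)c(Cl)c5)CC4)C(=O)O3)c2c1`, is not yet measured. It differs from compound 3 by 3,4-dichlorophenyl in place of cyclohexyl on a saturated chain carbon bound to an amine nitrogen in a ring. For the measured compounds named here, the only readable step that bears on it is the one from an aromatic to a saturated ring, a 6.3-fold higher number from compound 2 to compound 3 (0.80 log units; beyond the scatter), which went to a higher number. Returning to an aromatic ring, compound 4 is therefore expected to give a lower number, roughly reversing that step, with the estimate 2000 nM (range 500 nM to 8000 nM), meaning an expected step of a 4.0-fold lower number from compound 3 to compound 4 (0.60 log units; beyond the scatter).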

Compound 4, half-maximal inhibitory concentration: 126 nM
Estimate against measurement, compound 4: 16-fold (1.20 log units) above; measured number outside the range, below it.
By their numbers in this assay, from the lowest: compound 4; then compound 2; then compound 3.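

Placing 3,4-dichlorophenyl on a saturated chain carbon bound to an amine nitrogen in a ring gives a 63-fold lower number from compound 3 to compound 4 (1.80 log units; beyond the scatter) in place of cyclohexyl. In place of naphthalen-2-yl it gives a 10-fold lower number from compound 2 to compound 4 (1.00 log units; beyond the scatter), so the two aromatic groups at this position do not read alike. The step from compound 1 to compound 4 cannot be read, and compound 1 stands at a limit: the limit of < 50200 nM in this assay, at which 1 of the 4 values shown sits.

Open, as far as these compounds go, is whether both chlorines are needed, which 3-chlorophenyl and 4-chlorophenyl would test. Also open, from the compounds shown here alone, is how an unsubstituted phenyl or a 3,4-dimethoxyphenyl would read here.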